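Swapping the aryl group on a triazole-linked chromene

The compounds below may be only part of what the source reports. "The series", "measured", "known", "first", "only" and "open" are said of these compounds alone.

Compound 1 `CCOC(=O)C1=Cc2ccccc2OC1(OCc1cn(-c2ccc(F)c([N+](=O)[O-])c2)nn1)C(F)(F)F`: 16200 nM
Compound 2 `CCOC(=O)C1=Cc2ccccc2OC1(OCc1cc(-c2ccc(C)cc2)no1)C(F)(F)F`: > 150000 nM
Compound 3 `CCOC(=O)C1=Cc2ccccc2OC1(OCc1cn(-c2ccc(F)c(Cl)c2)nn1)C(F)(F)F`: 25300 nM

Three compounds share a core and were tested in a functional assay on MCF7 cells (Homo sapiens) for inhibition, read by MTT assay, with a stated time of 24 h; a lower number here means a stronger inhibitor, a higher number a weaker inhibitor. Compound 2 reached only a limit of the assay, (the limit of > 150000 nM in this assay, at which 1 of the 3 values shown sits). Among the two numbers, compound 3 stands highest, with compound 1 nearest; the single measured step, a 1.6-fold higher number from compound 1 to compound 3 (0.19 log units; within the scatter), lies within the scatter. Compound 4 `CCOC(=O)C1=Cc2ccccc2OC1(OCc1cn(-c2cccc(OC)c2)nn1)C(F)(F)F` differs from compound 3 by 3-methoxyphenyl in place of 3-chloro-4-fluorophenyl on an aromatic nitrogen. For the measured compounds named here, no measured step changes the group on this aromatic nitrogen, so the one step gives only weak guidance, and no change beyond the scatter is expected: compound 4 is estimated at 30000 nM, between 10000 nM and 100000 nM, an expected step of a 1.2-fold higher number from compound 3 to compound 4 (0.07 log units; within the scatter).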

Compound 4, half-maximal inhibitory concentration: > 150000 nM
Compound 4 was reported as a limit (the forecaster's own chance of this, stated with the estimate: 25%); middle value at least 5.0-fold (0.69 log units) from the limit.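

For the compounds shown here, this is the first measured change of the group on this aromatic nitrogen, and the group clearly matters: 3-methoxyphenyl in place of 3-chloro-4-fluorophenyl gives an at least 5.9-fold higher number from compound 3 to compound 4 (0.77 log units; beyond the scatter), and in place of 4-fluoro-3-nitrophenyl it gives an at least 9.2-fold higher number from compound 1 to compound 4 (0.96 log units; beyond the scatter). The value of compound 4 is a limit and not a number, so both steps give only a minimum size: the limit of > 150000 nM in this assay, at which 2 of the 4 values shown sit.

The change from compound 3 to compound 4 removes chlorine and fluorine and adds methoxy all at once, and the compounds shown cannot separate these parts. On these data alone, how an amine or a carboxylic acid on this phenyl ring would read also stays open.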